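A few compounds are considered here, and "the series" means these few. Any claim that something is new, unique, unknown or untested is made for them only; others in the source may bear on it.

Measured compounds:
- compound 1 `O=C(Nc1ccc(NCC2CCCC2)cc1Cl)c1cc(Cl)ccc1O`: 21500 nM
- compound 2 `O=C(Nc1ccc(NCc2ccc(F)cc2)cc1Cl)c1cc(Cl)ccc1O`: 54400 nM
- compound 3 `O=C(Nc1ccc(NCc2ccc(Cl)cc2)cc1Cl)c1cc(Cl)ccc1O`: 59700 nM

In an ADME assay on A549 cells (Homo sapiens) for cytotoxicity, read by resazurin assay, with a stated time of 48 h (a higher number here means that more compound is tolerated, a lower number that less compound is tolerated), compound 1 gives the lowest of the three numbers; compound 2 and compound 3 both stand higher, each by a modest step beyond the scatter, while compound 2 and compound 3 lie within the scatter of one another.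

Compound 4 `O=C(Nc1ccc(NCc2ccc(Br)s2)cc1Cl)c1cc(Cl)ccc1O` is not yet measured. Relative to compound 1 the change is 5-bromothiophen-2-yl in place of cyclopentyl on a saturated chain carbon bound to a nitrogen on an aromatic ring.

The two steps that bear on this change both exchange cyclopentyl for a ring placed on the saturated chain carbon bound to a nitrogen on an aromatic ring: a 2.5-fold higher number from compound 1 to compound 2 (0.40 log units; beyond the scatter) and a 2.8-fold higher number from compound 1 to compound 3 (0.44 log units; beyond the scatter). Both ran in the same direction and by about the same size, and the exchange of chloro for fluoro on an aromatic carbon, a 1.1-fold higher number from compound 2 to compound 3 (0.04 log units; within the scatter), made no difference beyond the scatter. The entering 5-bromothiophen-2-yl is likewise one five-membered aromatic ring with 1 hetero atom, so a modest rise in this assay is expected, of roughly the size seen for compound 2 and compound 3.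

For compound 4 the expected value is 45000 nM, with a range of 21000 nM to 95000 nM, which means an expected step of a 2.1-fold higher number from compound 1 to compound 4 (0.32 log units; beyond the scatter).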

Compound 4, half-maximal cytotoxic concentration: 20700 nM
Compound 4: middle estimate off by 2.2-fold (0.34 log units), on the high side; the whole stated range lies above it.
By their numbers in this assay, from the lowest: compounds 4 and 1 (each within the scatter of the next); then compounds 2 and 3 (each within the scatter of the next).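

The rise in this assay seen with 4-fluorophenyl and 4-chlorophenyl does not carry over to every aromatic ring on the saturated chain carbon bound to a nitrogen on an aromatic ring: 5-bromothiophen-2-yl in place of cyclopentyl leaves no step beyond the scatter (a 1.0-fold lower number from compound 1 to compound 4 (0.02 log units; within the scatter)). The position therefore distinguishes between aromatic rings, with compound 4 standing apart from both halogenated phenyl compounds (a 2.9-fold lower number from compound 3 to compound 4 (0.46 log units; beyond the scatter); a 2.6-fold lower number from compound 2 to compound 4 (0.42 log units; beyond the scatter)), whereas the exchange of chloro for fluoro made no difference beyond the scatter. Nothing in the available data explains this separation.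

Still open, as far as these compounds go, is whether the thiophene ring or its bromo substituent sets the lower number. Unsubstituted thiophen-2-yl and plain phenyl at this position would separate the two, and a basic amine on the ring would test a different kind of group.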